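Carboxylic acid to methyl ester on the shared core

This account rests on a few compounds, and the source may have more. Where it says the series, first, only, none or still open, it means among the compounds named here.

Compound 1 `CC#CCn1c(N2CCC[C@@H](N)C2)nc2c1c(=O)n(Cc1ccc(Br)cc1C(=O)O)c(=O)n2C` carries a 4-bromo-2-carboxyphenyl group on a saturated chain carbon bound to an aromatic nitrogen. In an ADME assay on isolated protein for inhibition of Dipeptidyl peptidase 9 (Homo sapiens), with stated times of 15 min, 60 s and 20 min (on this read-out lower numbers stand for stronger inhibition and higher numbers for weaker inhibition), compound 1 gives > 100000 nM, which is a limit of the assay rather than a number. Compound 2 `CC#CCn1c(N2CCC[C@@H](N)C2)nc2c1c(=O)n(Cc1ccccc1C(=O)OC)c(=O)n2C` is the plain methyl ester. In this assay compound 2 gives > 100000 nM, again a limit. Compound 3 `CC#CCn1c(N2CCC[C@@H](N)C2)nc2c1c(=O)n(Cc1cc(Cl)ccc1C(=O)OC)c(=O)n2C` adds a chloro group to that ester. In this assay compound 3 gives > 100000 nM, also a limit. The steps a step that the two limits leave unreadable from compound 1 to compound 2, a step that the two limits leave unreadable from compound 1 to compound 3 and a step that the two limits leave unreadable from compound 2 to compound 3 cannot be sized; all that can be said is the limit of > 100000 nM in this assay, at which 3 of the 3 values shown sit.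

Going by the values given here, compound 4 `CC#CCn1c(N2CCC[C@@H](N)C2)nc2c1c(=O)n(Cc1ccc(Cl)cc1C(=O)OC)c(=O)n2C` has not yet been measured. 4-chloro-2-(methoxycarbonyl)phenyl in place of 4-bromo-2-carboxyphenyl on a saturated chain carbon bound to an aromatic nitrogen Compound 4 shares the methyl ester of compound 2 and compound 3 and carries a halogen like all three, yet none of the measured steps that bear on it is readable, so no step size guides the expectation. The expected step is a step that the limit leaves unreadable from compound 1 to compound 4. Compound 4 is therefore expected to sit at the limit as well, with an estimate of 200000 nM and a range from 50000 nM to 1000000 nM.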

Compound 4, half-maximal inhibitory concentration in the Dipeptidyl peptidase 9 assay: > 100000 nM
Compound 4 was reported as a limit (the forecaster's own chance of this, stated with the estimate: 90%); the middle value does not contradict the limit.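

Compound 4 also gives a limit rather than a number in the Dipeptidyl peptidase 9 assay, so its steps from compound 1, compound 2 and compound 3 cannot be read: the limit of > 100000 nM in the Dipeptidyl peptidase 9 assay, at which 4 of the 4 values shown sit. In a physicochemical assay for metabolic stability, read by LC-MS, in phosphate buffer, with a stated time of 120 min, at pH 7.4, tested at 1 uM (on this read-out higher numbers stand for a more stable compound and lower numbers for a less stable compound), compound 1 gives 99.2% and compound 4 gives 101%. As far as these compounds go, whether any group on the shared core gives a readable number in the Dipeptidyl peptidase 9 assay stays open.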